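Moving one methoxy group: compound 3 to compound 4

A few compounds are considered here, and "the series" means these few. Any claim that something is new, unique, unknown or untested is made for them only; others in the source may bear on it.

Measured compounds in an ADME assay on HEK-293T cells (Homo sapiens) for inhibition, read by MTT assay, with a stated time of 48 h; a higher number here means a weaker inhibitor, a lower number a stronger inhibitor:
- compound 1 `COc1cc(-c2nc3cc(/C=C4\SC(=O)NC4=O)ccc3[nH]2)cc(OC)c1OC`: 13600 nM
- compound 2 `COc1cc(-c2nc3cc(/C=C4\SC(=O)NC4=O)ccc3[nH]2)ccc1OCC(C)C`: 14100 nM
- compound 3 `COc1cc(-c2nc3cc(/C=C4\SC(=O)N(CC(=O)N5CCOCC5)C4=O)ccc3[nH]2)cc(OC)c1OC`: 18800 nM

Compound 3 stands within the scatter of compound 2 and of compound 1; the three numbers do not separate. For the measured compounds named here, the only single-place step measured, a 1.4-fold higher number from compound 1 to compound 3 (0.14 log units; within the scatter), concerns the group on the amide-type ring nitrogen, not the aryl part, and stays within the scatter.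

Compound 4 `COc1cc(OC)c(-c2nc3cc(/C=C4\SC(=O)N(CC(=O)N5CCOCC5)C4=O)ccc3[nH]2)cc1OC` differs from compound 3 by 2,4,5-trimethoxyphenyl in place of 3,4,5-trimethoxyphenyl on an aromatic carbon. Going by the values given here, no measured step changes the arrangement of the methoxy groups on that ring. Compound 1 and compound 2 carry different aryl substitution and their values lie within the scatter of each other, which is the only indirect hint that the aryl pattern matters little here; that pair is not a single-place step, so it is taken only as a hint.

In this assay no step beyond the scatter is expected, so the estimate for compound 4 is 18000 nM, with a range of 8000 nM to 40000 nM, meaning an expected step of a 1.0-fold lower number from compound 3 to compound 4 (0.02 log units; within the scatter).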

Compound 4, half-maximal inhibitory concentration: 35700 nM
Beside the measured number, compound 4's estimate is 2.0-fold (0.30 log units) below it, and the stated range covers the measured number.
By their numbers in this assay, from the lowest: compounds 1, 2, 3 and 4 (each within the scatter of the next, the first and the last beyond it).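

In this assay, for the compounds shown here, the move of one methoxy group on the aryl ring, 2,4,5-trimethoxyphenyl in place of 3,4,5-trimethoxyphenyl, gives a 1.9-fold higher number from compound 3 to compound 4 (0.28 log units; within the scatter) and is the first single-place step at this aromatic carbon. With the same atoms in both groups and the ((morpholin-4-yl)carbonyl)methyl group on the ring nitrogen held fixed, this rearrangement stays within the scatter, so the arrangement of the methoxy groups is not shown to matter on this pair. Nothing at hand bears on what lies behind this step.

Open, on these data alone, is whether the same rearrangement gives a similar step with hydrogen on the ring nitrogen, as in compound 1. In this assay, as far as these compounds go, it also remains open how an aryl ring carrying an amine or a carboxylic acid in place of a methoxy group would read.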